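The compounds below may be only part of what the source reports. "The series", "measured", "known", "first", "only" and "open" are said of these compounds alone.

Compounds measured so far:
compound 1 `CCN(Cc1cc[nH]n1)C(=O)COc1ccc(C)cc1` — "not active" (no number reported)
compound 2 `Cc1ccc(OCC(=O)N(Cc2cccs2)c2ncco2)cc1` — 0.3 nM
compound 3 `CCN(Cc1cccs1)C(=O)COc1ccccc1` — 1400 nM

In an assay on HEK293 cells for agonist activity at transient receptor potential cation channel subfamily M member 8 (Homo sapiens), read by fluorescence and calcium flux, with a stated time of 15 min (a higher number here means that more compound is needed for the effect, a lower number that less compound is needed), compound 2 gives 0.3 nM, the lowest of the two numbers recorded. The nearest measured neighbour is compound 3, which in this assay gives 1400 nM, a gap that lies far beyond the scatter of repeated measurement. Compound 1 has no number in this assay and is recorded only as not active. Compounds 2 and 3 differ in more than one place, so no single change can be credited with the gap between them.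

The next compound, compound 4 `Cc1ccc(OCC(=O)N(Cc2cccs2)c2c(C)n[nH]c2C)cc1`, keeps the rest of compound 2 and changes one group on the amide-type nitrogen: 3,5-dimethyl-1H-pyrazol-4-yl in place of 1,3-oxazol-2-yl on an amide-type nitrogen.

Among the compounds with values here, no step between two measured compounds isolates this kind of change, so the size of the step in this assay cannot be read from the present set. The only weak pointers are that compound 2, with its five-membered aromatic ring directly on the nitrogen, is the strongest number, whereas compound 1, whose nitrogen carries an ethyl and a pyrazolylmethyl, gives "not active" (no number reported). A loss of potency of moderate to large size is expected, but with wide uncertainty in both directions. The step from compound 2 to compound 4 is estimated at a 100-fold higher number from compound 2 to compound 4 (2.00 log units; beyond the scatter). For compound 4 the expected value in this assay is 30 nM, within a range of 1 nM to 1000 nM.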

Compound 4, half-maximal effective concentration: 0.3 nM
The estimate for compound 4 lay 100-fold (2.00 log units) above the measured number; the measured number lies below the stated range.
By their numbers in this assay, from the lowest: compounds 2 and 4 (each within the scatter of the next); then compound 3.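

In this assay, within the data shown here, replacing 1,3-oxazol-2-yl with 3,5-dimethyl-1H-pyrazol-4-yl on the amide-type nitrogen gives no change at the digits printed from compound 2 to compound 4 (within the scatter), the first readable single-place step. This position therefore accepts two different five-membered aromatic rings with 2 hetero atoms, one with 5 heavy atoms and 0 hydrogen-bond donors and the other with 7 heavy atoms and 1 hydrogen-bond donor, without a change that can be read in this assay. No supporting measurement bears on why the two groups are interchangeable here, so the step stands as an observation only.

The step swaps the ring and brings in the two methyl groups together, so the unsubstituted 1H-pyrazol-4-yl group would be needed to separate these contributions, while a phenyl or pyridin-2-yl group on the same nitrogen would test whether a six-membered ring is accepted as well. Going by these compounds, it also remains open whether this equivalence holds with other groups elsewhere on the shared core, since it rests on a single pair of compounds.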